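This account rests on a few compounds, and the source may have more. Where it says the series, first, only, none or still open, it means among the compounds named here.

Among the compounds with values here, compound 2, `COc1ccc(F)cc1-c1cccc(-c2nn(CCCN)c(=O)o2)c1`, is the lower of the two compounds measured so far, though only by a little. In a functional assay on the whole organism (strain Wistar albino) for inhibition, with Rattus norvegicus as the target, read by paw edema, with stated times of 30 min and 2 h, at a dose of 10 mg/kg by the oral route (on this read-out lower numbers stand for less inhibition and higher numbers for more inhibition at the one dose given (going by the name of the read-out)), compound 2 gives 66%. Its nearest neighbour is compound 1, `COc1ccc(F)cc1-c1cccc(-c2nn(CCO)c(=O)o2)c1`, which in this assay gives 69%. Within the data shown here, the one step available, a number 3 percentage points lower from compound 1 to compound 2 (within the scatter), stays inside the usual scatter, so the two numbers cannot be told apart with confidence.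

Compound 3, `COC(=O)CCCn1nc(-c2cccc(-c3cc(F)ccc3OC)c2)oc1=O`, is not yet measured. Its difference from compound 2 is this: methoxycarbonyl in place of amino on a saturated chain carbon, three bonds along the chain from an aromatic nitrogen. Among the measured compounds shown here, the only measured step that bears on it is the one from compound 1 to compound 2, which also swapped the group at the end of the chain hanging from the aromatic nitrogen and moved the number by an amount within the scatter. With nothing beyond that to go on, a step of no real size in this assay is the reasonable expectation, perhaps a slight downward drift, so a number 4 percentage points lower from compound 2 to compound 3 (within the scatter) is the estimated step. Compound 3 is therefore expected to give about 62%, within a range from 45% to 78%.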

Compound 3, a percentage reported as inhibition, in the whole organism at one dose (the size of the read-out at that dose, not a potency): 74%
Beside the measured number, compound 3's estimate is 12 percentage points below it, within the range that was stated.
By their numbers in this assay, from the lowest: compounds 2, 1 and 3 (each within the scatter of the next).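

In this assay, putting methoxycarbonyl in place of the amino group on the chain gives a number 8 percentage points higher from compound 2 to compound 3 (within the scatter), and the 3-(methoxycarbonyl)propyl chain of compound 3 set against the hydroxy-ended chain of compound 1 gives a number 5 percentage points higher from compound 1 to compound 3 (within the scatter). The earlier pair showed only that hydroxy and amino ends could not be told apart, whereas this result extends that to a larger group with a double bond outside aromatic rings and no hydrogen-bond donor, so at this one dose the read-out does not separate any of the three chain ends. No other measurement is available to explain this result.

The compounds shown leave open whether any group at this chain end can produce a step beyond the scatter, such as a carboxylic acid, a simple amide or a dimethylamino group. They also leave open whether a shorter or longer chain carrying the same methoxycarbonyl group would stay level with compound 3, and whether these compounds would still be indistinguishable at other doses.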